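A few compounds are considered here, and "the series" means these few. Any claim that something is new, unique, unknown or untested is made for them only; others in the source may bear on it.

Of the compounds shown here, three built on one shared core have been tested for how much of them is needed to kill a culture of dog kidney cells. Compound 1 `Cc1nc([N+](=O)[O-])cn1CC(=O)NCc1ccccc1` gives 77600 nM in an ADME assay on MDCK cells (Canis lupus familiaris) for cytotoxicity, read by MTT assay, with a stated time of 72 h; on this read-out lower numbers stand for higher toxicity in this test and higher numbers for lower toxicity in this test. Compound 2 `Cc1nc([N+](=O)[O-])cn1CC(=O)Nc1c(Cl)cccc1Cl` gives 396000 nM in this assay. Compound 3 `Cc1nc([N+](=O)[O-])cn1S(=O)(=O)c1ccc([N+](=O)[O-])cc1` gives 611000 nM in this assay, the highest of the three numbers, though its gap to compound 2 lies within the scatter while its gap to compound 1 lies beyond it. Compound 4 `Cc1nc([N+](=O)[O-])cn1S(=O)(=O)c1ccc(Cl)cc1` differs from compound 3 by chloro in place of nitro on an aromatic carbon. For the measured compounds named here, no pair of measured compounds differs in a single place, so nothing measured guides this step; a step from compound 3 to compound 4 of a 1.2-fold lower number from compound 3 to compound 4 (0.09 log units; within the scatter) in this assay is expected, that is, none beyond the scatter. Compound 4 is estimated at 500000 nM, between 250000 nM and 1000000 nM.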

Compound 4, half-maximal cytotoxic concentration: 578000 nM
Estimate against measurement, compound 4: 1.2-fold (0.06 log units) below; the measured number falls inside the stated range.
By their numbers in this assay, from the lowest: compound 1; then compounds 2, 4 and 3 (each within the scatter of the next).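

Chloro in place of nitro, on an aromatic carbon para to a large group, is the first change in one place here, and in this assay it gives a 1.1-fold lower number from compound 3 to compound 4 (0.02 log units; within the scatter). In this one pair, then, the swap moves the number no further than the scatter, even though the entering group is a single chlorine atom and the leaving group has three heavy atoms. Nothing at hand explains this result.

The compounds shown leave open how an amine or a carboxylic acid at this position would read. They also leave open whether the same swap would read alike on another compound.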